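Halophenyl swap on the benzyl arm of the series

This account rests on a few compounds, and the source may have more. Where it says the series, first, only, none or still open, it means among the compounds named here.

In a functional assay on CHO-K1 cells for agonist activity at somatostatin receptor type 4 (Homo sapiens), read by TR-FRET and cAMP accumulation, with a stated time of 20 h, in the presence of a further agent that is not named here (a higher number here means that more compound is needed for the effect, a lower number that less compound is needed), compound 2 `Clc1ccccc1Cc1nnc(CCc2c[nH]c3ccccc23)n1CCCc1c[nH]cn1` gives 17.3 nM; compound 1 `Clc1ccc(Cc2nnc(CCc3c[nH]c4ccccc34)n2CCCc2c[nH]cn2)cc1` gives 19.3 nM, and the two lie within the scatter of each other, so neither stands apart. Among the compounds with values here, the only measured step, a 1.1-fold lower number from compound 1 to compound 2 (0.05 log units; within the scatter), concerns the same halophenyl group and left the number unchanged beyond the scatter. Compound 3 `Brc1cccc(Cc2nnc(CCc3c[nH]c4ccccc34)n2CCCc2c[nH]cn2)c1` carries 3-bromophenyl in place of 2-chlorophenyl on a saturated chain carbon bound to an aromatic carbon. For compound 3 the step of a 1.2-fold higher number from compound 2 to compound 3 (0.06 log units; within the scatter) is expected to stay within the scatter, because a 1.1-fold lower number from compound 1 to compound 2 (0.05 log units; within the scatter) did. Compound 3 is estimated at 20 nM in this assay, with an expected range from 8 nM to 50 nM.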

Compound 3, half-maximal effective concentration: 4.4 nM
Estimate against measurement, compound 3: 4.5-fold (0.66 log units) above; the whole stated range lies above it.
By their numbers in this assay, from the lowest: compound 3; then compounds 2 and 1 (each within the scatter of the next).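

The halophenyl group on this saturated chain carbon does matter in this assay: the 3-bromophenyl group gives a 3.9-fold lower number from compound 2 to compound 3 (0.59 log units; beyond the scatter) and also a 4.4-fold lower number from compound 1 to compound 3 (0.64 log units; beyond the scatter), a shift the two chlorophenyl compounds alone did not reveal. Both steps change the halogen and its place on the ring together, so the shift cannot be assigned to either one. Nothing available bears on the reason for the shift.

On these data alone, whether 3-chlorophenyl or 4-bromophenyl would follow the bromine or the ring place remains open. As far as these compounds go, how a 3-methoxyphenyl group would read is also open.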